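The source may hold more compounds than are shown below. What is called first, only, known or untested is meant among the compounds shown, and "the series" means these compounds.

In a functional assay on DU-145 cells (Homo sapiens) for inhibition, read by trypan blue exclusion, with a stated time of 96 h (a higher number here means a weaker inhibitor of growth, a lower number a stronger inhibitor of growth), compound 1 `Cc1ccc(CS/C(=C/c2c(O)cc(O)cc2O)C(=O)c2ccc(Cl)cc2)cc1` gives 50000 nM, compound 2 `Cc1ccc(CS/C(=C/c2ccc(Br)cc2)C(=O)c2ccc(Cl)cc2)cc1` gives 10000 nM and compound 3 `Cc1ccc(CS/C(=C/c2ccc(C)s2)C(=O)c2ccc(Cl)cc2)cc1` gives 50000 nM, which leaves compound 3 level with compound 1 as the highest of the three numbers. Compound 4 `Cc1ccc(CS/C(=C/c2cccc(Cl)c2Cl)C(=O)c2ccc(Cl)cc2)cc1` has 2,3-dichlorophenyl in place of 5-methylthiophen-2-yl on a double-bonded chain carbon bound to a double-bonded chain carbon. The nearest evidence is a 5.0-fold higher number from compound 2 to compound 3 (0.70 log units; beyond the scatter), a modest step at this same place, and a 5.0-fold lower number from compound 1 to compound 2 (0.70 log units; beyond the scatter) is of equal size. Only compound 2 carries a halogen-bearing phenyl there, as compound 4 does, so a modest step to a lower number is expected, though one measured case is thin support. The expected step is a 4.2-fold lower number from compound 3 to compound 4 (0.62 log units; beyond the scatter). For compound 4 the estimated value is 12000 nM, with an expected range of 3000 nM to 50000 nM.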

Compound 4, concentration for 50% growth inhibition: 25000 nM
The estimate for compound 4 lay 2.1-fold (0.32 log units) below the measured number; the measured number falls inside the stated range.
By their numbers in this assay, from the lowest: compound 2; then compounds 4, 1 and 3 (each within the scatter of the next).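

In this assay a second halogen-bearing phenyl does not reproduce compound 2, with a 2.5-fold higher number from compound 2 to compound 4 (0.40 log units; beyond the scatter) for this change on a double-bonded chain carbon, so a halogen on the phenyl is not enough to give that lower number. With a 2.0-fold lower number from compound 3 to compound 4 (0.30 log units; within the scatter) and a 2.0-fold lower number from compound 1 to compound 4 (0.30 log units; within the scatter) both within the scatter, 2,3-dichlorophenyl groups with 5-methylthiophen-2-yl and 2,4,6-trihydroxyphenyl, leaving compound 2 alone apart. No supporting information accounts for the gap between 4-bromophenyl and 2,3-dichlorophenyl. Still open, as far as these compounds go, is whether a single chlorine, a methoxy group or an amine on this phenyl would give a number like that of compound 2.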